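Dichlorophenyl for Hydroxyphenyl on the Saturated Ring Carbon

The source may report more compounds than this note shows. Statements on the series, on what has been measured and on what is new or still open speak of the compounds shown alone.

Going by the values given here, compound 1 `N#CC1=C(N)N(c2ccc(S(N)(=O)=O)cc2)C2=C(C(=O)CCC2)C1c1ccc(O)cc1` gives 100% in a functional assay on Ehrlich cells (Mus musculus) for antiproliferative activity, read by trypan blue exclusion, with a stated time of 2 h, tested at 100 ug/mL (on this read-out lower numbers stand for a weaker effect and higher numbers for a stronger effect at the one concentration tested), the highest of the two numbers measured so far, while its nearest neighbour, compound 2 `N#CC1=C(N)N(c2ccc(S(N)(=O)=O)cc2)C2=C(C(=O)CCC2)C1/C=C/c1ccccc1`, gives 45%. Among the compounds with values here, the single measured step, a number 55 percentage points lower from compound 1 to compound 2 (beyond the scatter), shows that an exchange of the group on the saturated ring carbon can lower the read-out deeply. Compound 3 `N#CC1=C(N)N(c2ccc(S(N)(=O)=O)cc2)C2=C(C(=O)CCC2)C1c1ccc(Cl)cc1Cl` has not yet been tested. It differs from compound 1 in one place: 2,4-dichlorophenyl in place of 4-hydroxyphenyl on a saturated ring carbon. Within the data shown here, no measured step follows this same exchange, so the step to compound 2 serves only as a rough sign that this position matters, and the outcome for a dichlorophenyl group remains open. A decrease smaller than the measured one is expected for compound 3, an expected step of a number 30 percentage points lower from compound 1 to compound 3 (beyond the scatter). Compound 3 is estimated at 70%, within a range from 30% to 100%.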

Compound 3, a percentage reported as activity, at one concentration (the size of the read-out at that concentration, not a potency): 95%
Estimate against measurement, compound 3: 25 percentage points below; the measured number falls inside the stated range.
By their numbers in this assay, from the lowest: compound 2; then compounds 3 and 1 (each within the scatter of the next).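

In this assay, the exchange of 4-hydroxyphenyl for 2,4-dichlorophenyl gives a number 5 percentage points lower from compound 1 to compound 3 (within the scatter), so at this saturated ring carbon the read-out holds even though the entering group has no hydrogen-bond donor or acceptor. The exchange of 2-phenylethenyl for 2,4-dichlorophenyl gives a number 50 percentage points higher from compound 2 to compound 3 (beyond the scatter), which shows that the drop seen with compound 2 does not come with every exchange here: among these three compounds, the two with a substituted phenyl group stay together and compound 2 stands apart. Nothing measured here gives a reason for these numbers.

On these data alone, whether a plain phenyl, a 4-aminophenyl, a 4-carboxyphenyl or a cyclohexyl group would hold the read-out remains open. As far as these compounds go, with a single concentration, it also remains open whether compound 1 and compound 3 would separate at lower doses.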